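Compound 2 to compound 3: methylsulfanyl to dimethylamino

The source may report more compounds than this note shows. Statements on the series, on what has been measured and on what is new or still open speak of the compounds shown alone.

In an ADME assay on L6 cells (Rattus norvegicus) for cytotoxicity (on this read-out higher numbers stand for weaker inhibition and lower numbers for stronger inhibition), compound 1 (`CCN(CC)c1ccc(NC2=NCCN2)cc1`) gives > 444000 nM, which is a limit of the assay and not a number. For the measured compounds named here, compound 2 (`CSc1ccc(NC2=NCCN2)cc1`) gives 174000 nM, the only true number so far, so its standing rests on a single comparison. Compound 3 (`CN(C)c1ccc(NC2=NCCN2)cc1`) has dimethylamino in place of methylsulfanyl on an aromatic carbon. Going by the values given here, the one measured step bearing on this change is an at least 2.5-fold lower number from compound 1 to compound 2 (0.40 log units; beyond the scatter), with methylsulfanyl in place of diethylamino, and its size is bounded only on one side. Compound 3 returns to an amino group of the kind in compound 1, so part of that step is expected to reverse, towards a higher number in this assay. The expected step is a 1.7-fold higher number from compound 2 to compound 3 (0.24 log units; within the scatter). For compound 3 the estimated value is 300000 nM, with an expected range of 150000 nM to 600000 nM.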

Compound 3, half-maximal inhibitory concentration: > 324000 nM
Compound 3 was reported as a limit (the forecaster's own chance of this, stated with the estimate: 35%); at least 1.0-fold (0.03 log units) between middle value and limit.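

In this assay compound 3 is reported only as a limit of the assay, not as a number: the limit of > 324000 nM in this assay, at which 1 of the 3 values shown sits. Dimethylamino in place of methylsulfanyl gives an at least 1.8-fold higher number from compound 2 to compound 3 (0.26 log units; that floor lies within the scatter), so the second amino-bearing compound also carries a limit, and compound 2 still holds the only true number. The step between the two limits, dimethylamino against diethylamino, cannot be read, so the compounds say nothing about the size of the amino group on this aromatic carbon.

Going by these compounds, how far either amino compound actually lies from compound 2 stays open, since the floor of the readable step gives no true size. A primary amine or a methoxy group on the same aromatic carbon could show whether methylsulfanyl stands apart from other small groups.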